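The source may report more compounds than this note shows. Statements on the series, on what has been measured and on what is new or still open speak of the compounds shown alone.

Measured so far:
- compound 1 `COc1ccc(N2CCN(c3nc(Nc4ccc(C#N)c(C(F)(F)F)c4)nc(Oc4ccnc5ccccc45)n3)CC2)cc1`; in a functional assay on DU-145 cells (Homo sapiens) for cytotoxicity, read by sulforhodamine B assay, with a stated time of 48 h (on this read-out lower numbers stand for stronger inhibition of growth and higher numbers for weaker inhibition of growth), compound 1 gives > 100000 nM
- compound 2 `N#Cc1ccc(Nc2nc(Oc3ccnc4ccccc34)nc(N3CCN(c4ncccn4)CC3)n2)cc1C(F)(F)F`; in this assay compound 2 gives 85200 nM

Among the measured compounds shown here, compound 2 carries the only number in this assay. The value of compound 1 is a limit of this assay and not a number (the limit of > 100000 nM in this assay, at which 1 of the 2 values shown sits). For the measured compounds named here, the one measured step, an at least 1.1-fold lower number from compound 1 to compound 2 (0.06 log units; that floor lies within the scatter), rests on that limit and lies within the scatter, so it shows no difference that can be read.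

Compound 3 `N#Cc1ccc(Nc2nc(Oc3ccnc4ccccc34)nc(N3CCN(c4cccc(Cl)c4Cl)CC3)n2)cc1C(F)(F)F` is not yet measured in this assay. It differs from compound 2 in one place: 2,3-dichlorophenyl in place of pyrimidin-2-yl on an amine nitrogen in a ring. The step from compound 1 to compound 2 is the only one that bears on this change, as it also replaces the group on that ring nitrogen, and it was within the scatter. Going by the values given here, no step here moves beyond the scatter, so nothing supports a change in either direction, and the weak inhibition of compound 2 is taken as the anchor.

Compound 3 is therefore expected to sit near compound 2, with a 1.1-fold lower number from compound 2 to compound 3 (0.03 log units; within the scatter) expected to be within the scatter. The estimate for compound 3 in this assay is 80000 nM, with a range from 25000 nM to 250000 nM.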

Compound 3, concentration for 50% growth inhibition: > 100000 nM
Compound 3 ended at the assay's limit; the forecaster's own chance of this, stated with the estimate: 35%; middle value at least 1.2-fold (0.09 log units) away from the limit.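

At the ring nitrogen, 2,3-dichlorophenyl now joins 4-methoxyphenyl, so neither of the two carbon-only aromatic rings shown there gives a number in this assay: the limit of > 100000 nM in this assay, at which 2 of the 3 values shown sit. Placing 2,3-dichlorophenyl where pyrimidin-2-yl stood gives an at least 1.1-fold higher number from compound 2 to compound 3 (0.06 log units; that floor lies within the scatter), so the change from a ring with two nitrogens to a chlorinated ring of carbon only produces no difference that can be read, and only a floor for its size is known. The step between compound 1 and compound 3 cannot be read: both values are limits.

Going by these compounds, whether any group on this ring nitrogen can bring the number down beyond the scatter remains open, as does the true size of the step from pyrimidin-2-yl to 2,3-dichlorophenyl. An open-chain group at this nitrogen, such as a short chain ending in an amine or a carboxylic acid, would differ in kind from the aromatic rings shown, and how such a group would read in this assay is unknown.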